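This account rests on a few compounds, and the source may have more. Where it says the series, first, only, none or still open, it means among the compounds named here.

Compounds measured so far:

compound 1 `C[Se]/C(=N\C(=O)c1cnc2ccccc2c1)NC(=O)c1cnc2ccccc2c1` — 660 nM in a functional assay on MCF7 cells (Homo sapiens) for cytotoxicity, read by MTT assay, with a stated time of 72 h; a lower number here means a stronger inhibitor of growth, a higher number a weaker inhibitor of growth
compound 2 `CS/C(=N\C(=O)c1cnc2ccccc2c1)NC(=O)c1cnc2ccccc2c1` — 23900 nM in this assay

Among the compounds with values here, compound 2 has the highest number of the two, with compound 1 the only neighbour for comparison. Within the data shown here, the single measured step bears directly on the change at hand: a 36-fold higher number from compound 1 to compound 2 (1.56 log units; beyond the scatter), the swap of the methylselanyl group of compound 1 for the methylsulfanyl group of compound 2. Compound 3 `O=C(/N=C(/NC(=O)c1cnc2ccccc2c1)[Se]Cc1ccccc1)c1cnc2ccccc2c1` reverses that swap and adds a benzyl group in place of the methyl: a group of 8 heavy atoms (7 carbon, 1 selenium; one six-membered aromatic ring of carbon only) in place of a group of 2 heavy atoms (1 carbon, 1 sulfur; no ring), on a carbon with a double bond to nitrogen. Because the step of a 36-fold higher number from compound 1 to compound 2 (1.56 log units; beyond the scatter) was large, the return to selenium is expected to bring the number down by a comparable amount; no measurement bears on the benzyl in place of methyl, so that part of the change remains unweighed. Compound 3 is therefore expected to give about 800 nM (range 200 nM to 4000 nM), a step of a 30-fold lower number from compound 2 to compound 3 (1.48 log units; beyond the scatter).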

Compound 3, concentration for 50% growth inhibition: 23600 nM
Beside the measured number, compound 3's estimate is 30-fold (1.47 log units) below it; measured number above the stated range.
By their numbers in this assay, from the lowest: compound 1; then compounds 3 and 2 (each within the scatter of the next).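

Compound 3 shows that selenium at this position does not by itself give the low number of compound 1: with phenyl in place of hydrogen on the saturated chain carbon bound to the selenium atom, there is a 36-fold higher number from compound 1 to compound 3 (1.55 log units; beyond the scatter) in this assay. The group on the carbon with a double bond to nitrogen therefore matters beyond the identity of the atom attached there, and the selenium-bearing group of compound 3 offers no gain over the methylsulfanyl group of compound 2, with a 1.0-fold lower number from compound 2 to compound 3 (0.01 log units; within the scatter) as the step. Nothing available explains either result.

The compounds shown leave open how a longer chain, such as ethyl on the selenium, would compare with the methyl of compound 1. They also leave open what phenyl would do on the sulfur series, or an amine or carboxylic acid at the end of the chain.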